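A Nitrogen Methyl Taken Away in Two Matched Pairs

The compounds below may be only part of what the source reports. "The series", "measured", "known", "first", "only" and "open" are said of these compounds alone.

This set covers three measured compounds and one not yet measured, all tested in a functional assay on thoracic aorta (Rattus norvegicus, strain Wistar), with a stated time of 15 min; on this read-out higher numbers stand for an effect only at larger amounts of compound and lower numbers for an effect already at smaller amounts. Compound 2 `CCOc1ccc(F)cc1C(C)NC(=O)N(C)S(=O)(=O)c1ccc(C)cc1` gives 7800 nM. Compound 1 `CCOc1ccc(F)cc1C(C)NC(=O)NS(=O)(=O)c1ccc(C)cc1` differs from compound 2 in one place: hydrogen in place of methyl on an amide-type nitrogen. In this assay compound 1 gives > 300000 nM, which is a limit of the assay rather than a number, the one recorded as the limit of > 300000 nM in this assay, at which 1 of the 3 values shown sits. The step itself is an at least 38-fold higher number from compound 2 to compound 1 (1.58 log units; beyond the scatter).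

Compound 3 `COc1ccc(Cl)cc1C(C)NC(=O)N(C)S(=O)(=O)c1ccc(Cl)cc1` has another core; how its core differs from that of compound 2 is not broken down here. In this assay compound 3 gives 20000 nM, the higher of the two numbers available, and its gap to compound 2 lies beyond the scatter.

Compound 4 `COc1ccc(Cl)cc1C(C)NC(=O)NS(=O)(=O)c1ccc(Cl)cc1` stands to compound 3 as compound 1 stands to compound 2: hydrogen in place of methyl on an amide-type nitrogen. The place is described word for word the same in both pairs, so this is the same change, made once more on a different core.

Compound 4 is expected to give 600000 nM in this assay, within a range from 150000 nM to 3000000 nM. Among the measured compounds shown here, that expectation rests on the single measured instance of this change, because an at least 38-fold higher number from compound 2 to compound 1 (1.58 log units; beyond the scatter) is large, and starting from the higher number of compound 3 the expected step is a 30-fold higher number from compound 3 to compound 4 (1.48 log units; beyond the scatter), which would most likely carry compound 4 past the point where the assay reports only a limit.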

Compound 4, half-maximal effective concentration: > 300000 nM
Compound 4: a limit, no number; the forecaster's own chance of this, stated with the estimate: 80%; the middle value lies beyond the limit too.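

On the second core the same change, methyl leaving the amide-type nitrogen and hydrogen entering, gives an at least 15-fold higher number from compound 3 to compound 4 (1.17 log units; beyond the scatter) in this assay, so the large upward move seen on the first core appears here as well. Compound 4 gives > 300000 nM, which is a limit of the assay and not a number, and compound 1 stops at that same limit: the limit of > 300000 nM in this assay, at which 2 of the 4 values shown sit. The change therefore carries over in direction between these two cores, but the true size of either step stays hidden, it is not shown whether the two sizes match, and two cores say nothing about a third: the same change on two cores in this assay, an at least 38-fold higher number (1.58 log units; beyond the scatter) from compound 2 to compound 1 and an at least 15-fold higher number (1.17 log units; beyond the scatter) from compound 3 to compound 4; the limit leaves it open whether they differ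

Going by these compounds, only methyl and hydrogen appear on this nitrogen, so it stays open whether an ethyl group or a longer chain there would give a readable number like those of compound 2 and compound 3. Also open, on these data alone, is how the methyl and hydrogen pair would behave on a core carrying an amine or a carboxylic acid.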